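The compounds below may be only part of what the source reports. "The series", "measured", "known", "first", "only" and "open" are said of these compounds alone.

Of the compounds shown here, three of this set have been tested in a functional assay on A549 cells (Homo sapiens) for antiproliferative activity, read by MTT assay, with a stated time of 72 h (on this read-out higher numbers stand for weaker inhibition and lower numbers for stronger inhibition), and none of them yields a number. Compound 1 `COc1ccc(Nc2ncnc3cc(OC)c(OCCCCC(=O)Nc4ccc(S(N)(=O)=O)cc4)cc23)cc1` gives > 40000 nM, which is a limit of the assay rather than a measured value. Compound 2 `COc1ccc(Nc2ncnc3cc(OC)c(OCCCCC(=O)Nc4ccc(S(N)(=O)=O)cc4)cc23)cc1OC` gives > 40000 nM, again only a limit. The step that the two limits leave unreadable from compound 1 to compound 2 therefore cannot be sized, because both of its ends rest at the limit of > 40000 nM in this assay, at which 3 of the 3 values shown sit. Compound 3 `NS(=O)(=O)c1ccc(NC(=S)Nc2ccc3ncnc(Nc4ccc(F)c(Br)c4)c3c2)cc1` gives > 40000 nM, once more a limit, so compound 3 stands exactly where every measured member of the set stands, with nothing to separate it from the others.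

Compound 4 `CCc1ccc(Nc2ncnc3ccc(NC(=S)Nc4ccc(S(N)(=O)=O)cc4)cc23)cc1` differs from compound 3 by 4-ethylphenyl in place of 3-bromo-4-fluorophenyl on a nitrogen on an aromatic ring. Going by the values given here, no measured step bears on this change: the only recorded step is unreadable, and the shared core of compound 3 and compound 4 has no other measured partner. With every measured compound at the limit, no direction can be argued, and the expected step that the limit leaves unreadable from compound 3 to compound 4 is none beyond the scatter. Compound 4 is accordingly expected near 60000 nM, within 15000 nM to 250000 nM, and most likely to be reported again as a limit.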

Compound 4, half-maximal inhibitory concentration: 24600 nM
For compound 4 the middle estimate is 2.4-fold (0.39 log units) above the measured one; the range from low to high includes it.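

In this assay compound 4 gives 24600 nM, the first read-out in this set that is a number. A change of group on this nitrogen on an aromatic ring can therefore bring the read-out off the limit. Putting 4-ethylphenyl in place of 3-bromo-4-fluorophenyl gives an at least 1.6-fold lower number from compound 3 to compound 4 (0.21 log units; that floor lies within the scatter), and this is only a floor, so the real step may be larger or may stay within the scatter. The step has no upper end because compound 3 rests at a limit: the limit of > 40000 nM in this assay, at which 3 of the 4 values shown sit.

The compounds shown leave open whether a hydroxyl group, an amine or a carboxylic acid in place of the ethyl group would shift the number further. They also leave open whether 4-ethylphenyl on the core of compound 1 would give a number at all.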